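Replacing 4-chlorophenyl in compound 3: expectation for compound 4

The compounds below may be only part of what the source reports. "The series", "measured", "known", "first", "only" and "open" are said of these compounds alone.

compound 1 `O=S(=O)(/C=C/c1ccccc1)Cc1ccc(Nc2ncnc3ccccc23)cc1`: 5000 nM
compound 2 `O=S(=O)(/C=C/c1ccc(Cl)c(Cl)c1)Cc1ccc(Nc2ncnc3ccccc23)cc1`: 22000 nM
compound 3 `O=S(=O)(/C=C/c1ccc(Cl)cc1)Cc1ccc(Nc2ncnc3ccccc23)cc1`: 54000 nM

In a functional assay on SK-OV-3 cells (Homo sapiens) (on this read-out higher numbers stand for weaker inhibition of growth and lower numbers for stronger inhibition of growth), compound 3 gives 54000 nM, the highest of the three numbers and so the weakest growth inhibition measured in this small set. Compound 4 `O=S(=O)(/C=C/c1ccc(C(F)(F)F)cc1F)Cc1ccc(Nc2ncnc3ccccc23)cc1` has not yet been measured. Its difference from compound 3 is 2-fluoro-4-(trifluoromethyl)phenyl in place of 4-chlorophenyl on a double-bonded chain carbon bound to a double-bonded chain carbon.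

For the measured compounds named here, three measured steps bear on this change, all at the same place. Adding chloro to the phenyl gives an 11-fold higher number from compound 1 to compound 3 (1.03 log units; beyond the scatter), a large step, and the 3,4-dichlorophenyl group gives a 4.4-fold higher number from compound 1 to compound 2 (0.64 log units; beyond the scatter), a modest one. The two chlorinated compounds also differ from each other, with a 2.5-fold higher number from compound 2 to compound 3 (0.39 log units; beyond the scatter). Going by the values given here, no measured compound carries fluoro or trifluoromethyl, so these steps guide the estimate only loosely. Compound 3 stands at the top of the range, and compound 2, also substituted, gives 22000 nM. A small move toward a lower number is therefore expected, with the expected step being a 1.8-fold lower number from compound 3 to compound 4 (0.26 log units; within the scatter). The estimated value for compound 4 is 30000 nM, with an expected range of 10000 nM to 80000 nM.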

Compound 4, concentration for 50% growth inhibition: 39000 nM
Beside the measured number, compound 4's estimate is 1.3-fold (0.11 log units) below it, and the stated range covers the measured number.
By their numbers in this assay, from the lowest: compound 1; then compounds 2, 4 and 3 (each within the scatter of the next, the first and the last beyond it).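

In this assay, the position on the double-bonded chain carbon also tolerates 2-fluoro-4-(trifluoromethyl)phenyl, a group with no chlorine, without separating it from the two chlorinated groups: the result is a 1.4-fold lower number from compound 3 to compound 4 (0.14 log units; within the scatter) and a 1.8-fold higher number from compound 2 to compound 4 (0.25 log units; within the scatter). The gap to the unsubstituted phenyl remains, at a 7.8-fold higher number from compound 1 to compound 4 (0.89 log units; beyond the scatter), so among these four compounds all three substituted phenyl groups give higher numbers than phenyl itself, with none going against this, and the pattern now reaches beyond chloro to fluoro and trifluoromethyl. Nothing available gives a reason for this pattern or for the closeness of compound 4 to the chlorinated compounds.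

The compounds shown do not separate the contribution of the fluoro from that of the trifluoromethyl in compound 4, so either one alone could account for its number. Also open, on these data alone, is whether a substituent without halogen on this phenyl, such as methoxy, an amine or a carboxylic acid, stays with the substituted compounds or returns toward compound 1 at 5000 nM.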